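The source may hold more compounds than are shown below. What is called first, only, known or untested is meant among the compounds shown, and "the series" means these compounds.

Compound 1 `CCCC(=O)C1=C(C)NC(=O)NC1c1ccoc1`, compound 2 `CCCC(=O)C1=C(C)NC(=O)NC1c1cccs1` and compound 3 `CCNC(=O)C1=C(C)NC(=O)NC1c1ccoc1` have been measured, while compound 4 `CCNC(=O)C1=C(C)NC(=O)NC1c1cccs1` has not. In an assay on membranes from HeLa cells for displacement of a labelled ligand from adenosine receptor A3 (Homo sapiens), read by scintillation counting, with a stated time of 180 min, tested at 1 uM (a lower number here means less inhibition, a higher number more inhibition at the concentration tested (going by the name of the read-out)), compound 1 gives 2%, compound 2 gives 2% and compound 3 gives 1%. The change from compound 1 to compound 2, (thiophen-2-yl in place of furan-3-yl on a saturated ring carbon), made a step of no change at the digits printed from compound 1 to compound 2 (within the scatter). The change from compound 3 to compound 4 is thiophen-2-yl in place of furan-3-yl on a saturated ring carbon, the same kind of change, but on a different core, since the two cores differ by ethylamino in place of propyl on a carbonyl carbon; in compound 4 the saturated ring carbon is next to the ring atom that bears an ethylcarbamoyl group, where in compound 2 that ring atom bears a propylcarbonyl group. Because compound 3 gives 1% and the earlier step was no change at the digits printed from compound 1 to compound 2 (within the scatter), the step from compound 3 to compound 4 is expected to be a number 1 percentage points higher from compound 3 to compound 4 (within the scatter). Compound 4 is therefore estimated at 2%.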

Compound 4, a percentage reported as inhibition, at one concentration (the size of the read-out at that concentration, not a potency): 4%
For compound 4 the middle estimate is 2 percentage points below the measured one; the range from low to high includes it.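

In this assay, thiophen-2-yl in place of furan-3-yl gives a number 3 percentage points higher from compound 3 to compound 4 (within the scatter), which agrees with the same change on the other core: the same change on two cores in this assay, no change at the digits printed (within the scatter) from compound 1 to compound 2 and a number 3 percentage points higher (within the scatter) from compound 3 to compound 4, 3 percentage points apart, within the scatter of two such steps

Ethylamino in place of propyl on the carbonyl carbon gives a number 2 percentage points higher from compound 2 to compound 4 (within the scatter), and this also agrees across the two cores: the same change on two cores in this assay, a number 1 percentage points lower (within the scatter) from compound 1 to compound 3 and a number 2 percentage points higher (within the scatter) from compound 2 to compound 4, 3 percentage points apart, within the scatter of two such steps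

Neither change moves the read-out beyond the scatter on either core, so this is agreement among small numbers and does not show that a step of real size would carry from one core to another.

The compounds shown leave open whether a longer chain on the carbonyl carbon, or a phenyl ring in place of the furan-3-yl or thiophen-2-yl group, would give clear inhibition in this assay.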